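Methoxy for Fluoro on a Benzothiazole Pair

The source may hold more compounds than are shown below. What is called first, only, known or untested is meant among the compounds shown, and "the series" means these compounds.

Measured so far:
compound 1 `Cc1ccc(-c2ccc(F)cc2)n1-c1ccc(-c2nc3ccc(F)cc3s2)cc1` gives 3030 nM in a functional assay on MDA-MB-231 cells (Homo sapiens) for cytotoxicity, read by sulforhodamine B assay, with a stated time of 48 h; a lower number here means a stronger inhibitor of growth, a higher number a weaker inhibitor of growth;
compound 2 `COc1cc(-c2ccc(C)n2-c2ccc(-c3nc4ccc(F)cc4s3)cc2)cc(OC)c1OC` gives 3000 nM in this assay;
compound 3 `COc1ccc2nc(-c3ccc(-n4c(C)ccc4-c4ccc(F)cc4)cc3)sc2c1` gives 4060 nM in this assay.

Compound 3 differs from compound 1 by methoxy in place of fluoro on an aromatic carbon, and that step reads a 1.3-fold higher number from compound 1 to compound 3 (0.13 log units; within the scatter), so the two numbers sit within the scatter of each other. Compound 2 differs from compound 1 in more than one place; the difference between the two cores is not broken down here, and its value lies within the scatter of those of compound 1 and compound 3.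

Compound 4 `COc1ccc2nc(-c3ccc(-n4c(C)ccc4-c4cc(OC)c(OC)c(OC)c4)cc3)sc2c1` has not yet been measured. It differs from compound 2 by methoxy in place of fluoro on an aromatic carbon, the same change as from compound 1 to compound 3, at a place described in the same words. Since compound 1 and compound 3 gave a 1.3-fold higher number from compound 1 to compound 3 (0.13 log units; within the scatter), a step of about a 1.3-fold higher number from compound 2 to compound 4 (0.11 log units; within the scatter) is expected here in this assay, resting on that single earlier pair. Compound 4 is therefore estimated at 3900 nM in this assay, between 2000 nM and 8000 nM.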

Compound 4, concentration for 50% growth inhibition: 1760 nM
For compound 4 the middle estimate is 2.2-fold (0.35 log units) above the measured one; the measured number lies below the stated range.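

In this assay, methoxy in place of fluoro on the core of compound 2 gives a 1.7-fold lower number from compound 2 to compound 4 (0.23 log units; within the scatter), and on the core of compound 1 the same change gives a 1.3-fold higher number from compound 1 to compound 3 (0.13 log units; within the scatter), so neither core shows a step that can be told from the scatter. The gap between the two steps can be told from it no better: the same change on two cores in this assay, a 1.3-fold higher number (0.13 log units; within the scatter) from compound 1 to compound 3 and a 1.7-fold lower number (0.23 log units; within the scatter) from compound 2 to compound 4, 2.3-fold (0.36 log units) apart, within the scatter of two such steps Within these two pairs, then, the change carries from one core to the other without a detectable dependence on the core, but two pairs cannot show that the cores respond alike, nor that the change is without effect on either of them.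

From the compounds shown here alone, only fluoro and methoxy appear at this place on the 1,3-benzothiazol-2-yl group, so it remains open how an amine, a carboxylic acid or a longer alkoxy chain would read there. Also open, going by these compounds, is whether the change would read the same way on cores other than these two.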